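This account rests on a few compounds, and the source may have more. Where it says the series, first, only, none or still open, it means among the compounds named here.

Three compounds share one core and differ only in the ring attached to the sulfur. In an in vitro assay on cells for inhibition of Amine oxidase [flavin-containing] B (Homo sapiens), read by coupled enzyme assay, with a stated time of 20 min (a lower number here means a stronger inhibitor, a higher number a weaker inhibitor), compound 1 `Cn1c(=O)c2c(nc(CCSc3cccc(Br)c3)n2C)n(C)c1=O` gives 64100 nM, compound 2 `Cn1c(=O)c2c(nc(CCSc3ccc(Cl)cc3)n2C)n(C)c1=O` gives 7790 nM, and compound 3 `Cn1c(=O)c2c(nc(CCSc3cccc(Cl)c3)n2C)n(C)c1=O` gives 5670 nM, the lowest number of the three; compound 2 sits within the scatter of it, while compound 1 lies well beyond. Compound 4 `Cn1c(=O)c2c(nc(CCSc3ccc(Br)cc3)n2C)n(C)c1=O` carries 4-bromophenyl in place of 3-chlorophenyl on a sulfur. Among the compounds with values here, two steps bear on this. Swapping the halogen gave an 11-fold lower number from compound 1 to compound 3 (1.05 log units; beyond the scatter), and the combined change gave an 8.2-fold lower number from compound 1 to compound 2 (0.92 log units; beyond the scatter), whereas moving chlorine alone gave only a 1.4-fold lower number from compound 2 to compound 3 (0.14 log units; within the scatter). Because compound 1 shows 64100 nM with a bromine, a higher number is expected for compound 4, about a 6.2-fold higher number from compound 3 to compound 4 (0.79 log units; beyond the scatter). Compound 4 is estimated at 35000 nM, between 8000 nM and 150000 nM.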

Compound 4, half-maximal inhibitory concentration: 124000 nM
Estimate against measurement, compound 4: 3.5-fold (0.55 log units) below; the range from low to high includes it.
By their numbers in this assay, from the lowest: compounds 3 and 2 (each within the scatter of the next); then compounds 1 and 4 (each within the scatter of the next).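

The halogen, not its place on the ring, accounts for the large steps in this set. Bromo in place of chloro on the para-free comparison also raises the number, a 16-fold higher number from compound 2 to compound 4 (1.20 log units; beyond the scatter), and the change from 3-chlorophenyl to 4-bromophenyl gives a 22-fold higher number from compound 3 to compound 4 (1.34 log units; beyond the scatter). Moving the bromine stays within the scatter, a 1.9-fold higher number from compound 1 to compound 4 (0.29 log units; within the scatter), and the halogen swap repeats in size on both ring patterns: the same change on two cores in this assay, an 11-fold lower number (1.05 log units; beyond the scatter) from compound 1 to compound 3 and a 16-fold lower number (1.20 log units; beyond the scatter) from compound 4 to compound 2, 1.4-fold (0.15 log units) apart, within the scatter of two such steps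

As far as these compounds go, whether a fluoro or methoxy group on the ring would give a lower number remains open. So does the effect of a longer chain on the sulfur.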